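A few compounds are considered here, and "the series" means these few. Any claim that something is new, unique, unknown or untested is made for them only; others in the source may bear on it.

All three measured compounds, and compound 4 as well, share the same core and differ only in the amide-bearing aromatic ring and in the amine at the end of the chain. Compound 3 `COc1cc2c(Nc3nc4ccc(C(=O)Nc5c(C)cccc5C)cc4s3)ncnc2cc1OCCCN1CCCCC1C` gives 12300 nM in a functional assay on K562 cells (Homo sapiens) for cytotoxicity, read by WST assay, with a stated time of 72 h (on this read-out lower numbers stand for stronger inhibition and higher numbers for weaker inhibition), the highest of the three numbers. For the measured compounds named here, compound 2 `COc1cc2c(Nc3nc4ccc(C(=O)Nc5c(C)cccc5Cl)cc4s3)ncnc2cc1OCCCN1CCCCC1C` gives 6800 nM in this assay, and the single change between them, a 1.8-fold higher number from compound 2 to compound 3 (0.26 log units; within the scatter), stays within the scatter. Going by the values given here, compound 1 `COc1cc2c(Nc3nc4ccc(C(=O)Nc5c(C)cc(C)cc5C)cc4s3)ncnc2cc1OCCCN1CCC(C)CC1` gives 5900 nM in this assay; it differs from compound 3 in two places at once, so no single step connects the two, and its number lies beyond the scatter below that of compound 3.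

Compound 4 `COc1cc2c(Nc3nc4ccc(C(=O)Nc5c(C)cc(C)cc5C)cc4s3)ncnc2cc1OCCCN1CCCCC1C` arises from compound 3 by methyl in place of hydrogen on an aromatic carbon. Among the compounds with values here, no measured pair differs by this change alone, so no step speaks to it directly. The nearest hint is compound 1, which carries the same 2,4,6-trimethylphenyl group on a different amine and gives 5900 nM in this assay. Compound 4 is therefore expected to show a modest downward step, a 1.5-fold lower number from compound 3 to compound 4 (0.19 log units; within the scatter), with an estimated value of 8000 nM and a range from 3000 nM to 20000 nM.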

Compound 4, half-maximal inhibitory concentration: 3500 nM
For compound 4 the middle estimate is 2.3-fold (0.36 log units) above the measured one; the measured number falls inside the stated range.
By their numbers in this assay, from the lowest: compounds 4, 1, 2 and 3 (each within the scatter of the next, the first and the last beyond it).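

Adding a methyl group on the aromatic carbon para to a large group, which turns 2,6-dimethylphenyl into 2,4,6-trimethylphenyl, gives the first single change in this assay to lie beyond the scatter: a 3.5-fold lower number from compound 3 to compound 4 (0.55 log units; beyond the scatter) is a clearer step than the swap of chloro for methyl on the same ring, a 1.8-fold higher number from compound 2 to compound 3 (0.26 log units; within the scatter). The other two comparisons show much less: 2,4,6-trimethylphenyl in place of 2-chloro-6-methylphenyl gives a 1.9-fold lower number from compound 2 to compound 4 (0.29 log units; within the scatter) and 2-methylpiperidin-1-yl in place of 4-methylpiperidin-1-yl gives a 1.7-fold lower number from compound 1 to compound 4 (0.23 log units; within the scatter), and both stay within the scatter, so neither change can be told apart from repeat-measurement noise. Nothing available here explains why the added methyl group goes with a lower number.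

The compounds shown carry only hydrogen or methyl at this ring position, so whether an ethyl group, a methoxy group or a chlorine atom there would give a similar number stays open. On these data alone, it also stays open whether the same step would appear with the 4-methylpiperidin-1-yl amine, or with a morpholine or a dimethylamino group at the end of the chain.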